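Side chain swap on the shared core: compound 3 to compound 4

The compounds below may be only part of what the source reports. "The series", "measured", "known", "first", "only" and "open" are said of these compounds alone.

Compound 1 `CCOC(=O)/C(C#N)=C/c1nc(-c2ccc(OC)cc2)c(-c2ccc(OC)cc2)s1`: > 100 uM (a limit)
Compound 2 `CCOC(=O)/C=C/c1nc(-c2ccc(OC)cc2)c(-c2ccc(OC)cc2)s1`: > 100 uM (a limit)
Compound 3 `COc1ccc(-c2nc(CCC(=O)O)sc2-c2ccc(OC)cc2)cc1`: > 100 uM (a limit)

In a functional assay (aorta) with Rattus norvegicus as the target (on this read-out higher numbers stand for an effect only at larger amounts of compound and lower numbers for an effect already at smaller amounts), compound 3 gives > 100 uM, which is a limit and not a number. Among the compounds with values here, the series so far sits entirely at the limit of > 100 uM in this assay, at which 3 of the 3 values shown sit. Compound 4 `COc1ccc(-c2nc(C3=CCN(C)CC3)sc2-c2ccc(OC)cc2)cc1` carries the change (a group of 7 heavy atoms (6 carbon, 1 nitrogen; one six-membered non-aromatic ring with 1 hetero atom) in place of a group of 5 heavy atoms (3 carbon, 2 oxygen; no ring), on an aromatic carbon). Within the data shown here, three measured steps concern the same aromatic carbon: a step that the two limits leave unreadable from compound 1 to compound 2, a step that the two limits leave unreadable from compound 1 to compound 3 and a step that the two limits leave unreadable from compound 2 to compound 3. None has a readable size, so they give no expected direction in this assay. The expected step is a number no higher from compound 3 to compound 4 (the limit leaves the size open), an estimate that stays near the limit. For compound 4 the estimated value is 100 uM, with an expected range of 30 uM to 300 uM.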

Compound 4, concentration for half-maximal effect: 5.9 uM
Compound 4: the middle estimate sits 17-fold (1.23 log units) above what was measured; the whole stated range lies above it.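

Within the data shown here, this aromatic carbon is the first place where a change brings the read-out in this assay off the limit: the limit of > 100 uM in this assay, at which 3 of the 4 values shown sit. The six-membered non-aromatic ring with its nitrogen gives an at least 16-fold lower number from compound 3 to compound 4 (1.22 log units; beyond the scatter), and the same change gives an at least 16-fold lower number from compound 2 to compound 4 (1.22 log units; beyond the scatter) and an at least 16-fold lower number from compound 1 to compound 4 (1.22 log units; beyond the scatter), so all three replaced side chains, none of which has a ring, lie well apart from it.

The compounds shown leave open whether the ring or its nitrogen goes with this step. An open-chain amine such as 2-(dimethylamino)ethyl on this carbon, or the ring without its methyl group, would separate the two.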